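The source may report more compounds than this note shows. Statements on the series, on what has been measured and on what is new or still open speak of the compounds shown alone.

Measured compounds:
compound 1, `COc1cc(Nc2nc(Nc3ccc(Br)cc3)nnc2Cl)cc(OC)c1OC`, 11400 nM
compound 2, `COc1ccc(Nc2nnc(Cl)c(Nc3cc(OC)c(OC)c(OC)c3)n2)cc1`, 19000 nM
compound 3, `COc1cc(Nc2nc(Nc3ccc(C(C)=O)cc3)nnc2Cl)cc(OC)c1OC`, 13000 nM

In a functional assay on MGC-803 cells (Homo sapiens) for inhibition, read by MTT assay, with a stated time of 48 h (on this read-out lower numbers stand for stronger inhibition and higher numbers for weaker inhibition), compound 3 holds the second highest of these three numbers. The nearest is compound 1, since there is a 1.1-fold higher number from compound 1 to compound 3 (0.06 log units; within the scatter); the furthest is compound 2, with a 1.5-fold lower number from compound 2 to compound 3 (0.16 log units; within the scatter). Compound 4 `COc1cc(Nc2nc(Nc3ccc(Cl)cc3)nnc2Cl)cc(OC)c1OC` differs from compound 3 in one place: chloro in place of acetyl on an aromatic carbon. For the measured compounds named here, the steps that bear on this exchange are a 1.1-fold higher number from compound 1 to compound 3 (0.06 log units; within the scatter), a 1.7-fold higher number from compound 1 to compound 2 (0.22 log units; within the scatter) and a 1.5-fold lower number from compound 2 to compound 3 (0.16 log units; within the scatter); each swap at this position stayed within the scatter. The expected step is therefore a 1.1-fold lower number from compound 3 to compound 4 (0.03 log units; within the scatter), nothing beyond the scatter. Compound 4 is estimated at 12000 nM, with a range from 5500 nM to 26000 nM.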

Compound 4, half-maximal inhibitory concentration: 12600 nM
Estimate against measurement, compound 4: 1.1-fold (0.02 log units) below; the range from low to high includes it.
By their numbers in this assay, from the lowest: compounds 1, 4, 3 and 2 (each within the scatter of the next).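

In this assay, chloro gives a number level with that of acetyl (a 1.0-fold lower number from compound 3 to compound 4 (0.01 log units; within the scatter)), methoxy (a 1.5-fold lower number from compound 2 to compound 4 (0.18 log units; within the scatter)) and bromo (a 1.1-fold higher number from compound 1 to compound 4 (0.04 log units; within the scatter)). Swapping the acetyl, with 3 heavy atoms, for a chloro, with 1 heavy atom, therefore leaves the number within the scatter, and all four groups at this position now read alike. No measurement shown here explains this result. Still open, going by these compounds, is whether an amine, a carboxylic acid or a longer chain at this position would give a step beyond the scatter.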